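The source may hold more compounds than are shown below. What is called first, only, known or untested is meant among the compounds shown, and "the series" means these compounds.

In a functional assay on HepG2 cells (Homo sapiens) for inhibition, read by MTT assay, with a stated time of 24 h (a higher number here means a weaker inhibitor, a lower number a stronger inhibitor), compound 1 `Cc1ccccc1-n1cc(CN2C(=O)C[C@@H]3CC[C@@]2(C)C3(C)C)nn1` gives 150 nM, compound 2 `CC1(C)[C@H]2CC[C@]1(C)N(Cc1cn(-c3ccc(Cl)cc3)nn1)C(=O)C2` gives 90 nM and compound 3 `COc1cccc(-n2cc(CN3C(=O)C[C@@H]4CC[C@@]3(C)C4(C)C)nn2)c1` gives 70 nM. The data show a 1.3-fold lower number from compound 2 to compound 3 (0.11 log units; within the scatter) and a 2.1-fold lower number from compound 1 to compound 3 (0.33 log units; beyond the scatter), so compound 3 stands level with one neighbour and clear of the other. Compound 4 `COc1ccc(-n2cc(CN3C(=O)C[C@@H]4CC[C@@]3(C)C4(C)C)nn2)cc1` keeps the shared core and has 4-methoxyphenyl in place of 3-methoxyphenyl on an aromatic nitrogen. For the measured compounds named here, no measured step makes this exact swap, but changing the group on that nitrogen gave only small steps, such as a 1.7-fold lower number from compound 1 to compound 2 (0.22 log units; within the scatter). In this assay, no shift beyond the scatter is therefore expected. The expected result is a 1.3-fold higher number from compound 3 to compound 4 (0.11 log units; within the scatter). Compound 4 is estimated at 90 nM, with an expected range of 40 nM to 200 nM.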

Compound 4, half-maximal inhibitory concentration: 100 nM
Beside the measured number, compound 4's estimate is 1.1-fold (0.05 log units) below it; the range from low to high includes it.
By their numbers in this assay, from the lowest: compounds 3, 2, 4 and 1 (each within the scatter of the next, the first and the last beyond it).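

In this assay, the methoxy group's place on the phenyl ring makes no difference beyond the scatter: 4-methoxyphenyl in place of 3-methoxyphenyl gives a 1.4-fold higher number from compound 3 to compound 4 (0.15 log units; within the scatter) and so does not separate the two isomers. Methoxy in place of chloro gives a 1.1-fold higher number from compound 2 to compound 4 (0.05 log units; within the scatter) and 4-methoxyphenyl in place of 2-methylphenyl gives a 1.5-fold lower number from compound 1 to compound 4 (0.18 log units; within the scatter), so these swaps also stay within the scatter. Nothing available explains these results. From the compounds shown here alone, whether an amine, a carboxylic acid or a longer chain on the phenyl ring would give a step beyond the scatter remains open.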